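Series notes: substituent change at the double-bonded ring carbon

The source may hold more compounds than are shown below. What is called first, only, known or untested is meant among the compounds shown, and "the series" means these compounds.

Of the compounds shown here, two have been measured. Compound 1 `CCOC(=O)C1=C(C)NC(CCl)=C(C(=O)OCC)C1c1cccc([N+](=O)[O-])c1` in a functional assay on HEK293 cells for antagonist activity at Voltage-dependent L-type calcium channel subunit alpha-1D (Rattus norvegicus), read by FLIPR (on this read-out lower numbers stand for stronger inhibition and higher numbers for weaker inhibition), gives 53 nM. Within the data shown here, compound 2 `CCOC(=O)C1=C(C)NC(C(OCC)OCC)=C(C(=O)OCC)C1c1cccc([N+](=O)[O-])c1` in this assay gives 615 nM, the highest of the two numbers so far; its nearest neighbour is compound 1, and the step of a 12-fold higher number from compound 1 to compound 2 (1.06 log units; beyond the scatter) is the only one recorded between compounds that differ in one place. Compound 3 `CCOC(=O)C1=C(C)NC(/C=C/C#N)=C(C(=O)OCC)C1c1cccc([N+](=O)[O-])c1` is not yet measured. It differs from compound 2 by 2-cyanoethenyl in place of diethoxymethyl on a double-bonded ring carbon. Among the measured compounds shown here, no measured step covers this exchange directly; the one that bears on it is a 12-fold higher number from compound 1 to compound 2 (1.06 log units; beyond the scatter), which shows that exchanging the group on this ring carbon moved the number by a large step, with the diethoxymethyl group carrying the weaker value. The 2-cyanoethenyl group is neither of the two groups already measured, so the direction rests on that single step alone. The expectation is that compound 3 returns a number between the two measured ones, the step of a 4.1-fold lower number from compound 2 to compound 3 (0.61 log units; beyond the scatter) being estimated downward. Compound 3 is expected at 150 nM with a range of 40 nM to 600 nM.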

Compound 3, half-maximal inhibitory concentration: 45 nM
Compound 3: middle estimate off by 3.3-fold (0.52 log units), on the high side; low and high end bracket the measured number.
By their numbers in this assay, from the lowest: compounds 3 and 1 (each within the scatter of the next); then compound 2.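

In this assay, 2-cyanoethenyl in place of diethoxymethyl on the double-bonded ring carbon next to the ring nitrogen gives a 14-fold lower number from compound 2 to compound 3 (1.14 log units; beyond the scatter), so a second group now separates from diethoxymethyl by a large step, and the earlier result no longer rests on chloromethyl alone. Chloromethyl and 2-cyanoethenyl cannot be told apart, with a 1.2-fold lower number from compound 1 to compound 3 (0.07 log units; within the scatter), which leaves compound 2 as the only one of the three that stands apart, with the weakest inhibition, even though the two other groups differ in kind and only 2-cyanoethenyl carries a double and a triple bond outside aromatic rings. Nothing on hand accounts for why diethoxymethyl alone stands apart at this position.

The compounds shown leave open how an aminomethyl group, a hydroxymethyl group or a carboxylic acid on this ring carbon would read, and so whether diethoxymethyl is an isolated case among such groups. They also leave open whether a longer chain ending in a nitrile would keep the level shared by compound 1 and compound 3.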